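The source may hold more compounds than are shown below. What is called first, only, known or untested is meant among the compounds shown, and "the series" means these compounds.

Three compounds of the series are in hand. Compound 1 `O=C(c1cc(Oc2cccc(NC(=S)Nc3cccc(C(F)(F)F)c3)c2)ccn1)N1CCCC1` pairs a (pyrrolidin-1-yl)carbonyl with a trifluoromethyl-bearing thiourea end; in a functional assay on MDA-MB-231 cells (Homo sapiens) for cytotoxicity, read by MTT assay, with a stated time of 48 h (a higher number here means a weaker inhibitor, a lower number a stronger inhibitor), compound 1 gives 35400 nM. Compound 2 `CNC(=O)c1cc(Oc2cccc(NC(=S)Nc3ccc(OC(F)(F)F)cc3)c2)ccn1` and compound 3 `CC(C)NC(=O)c1cc(Oc2cccc(NC(=S)Nc3ccc(OC(F)(F)F)cc3)c2)ccn1` carry the trifluoromethoxy-bearing thiourea end with a methyl amide and an isopropyl amide. In this assay compound 2 reaches only the limit > 100000 nM. Compound 3 likewise reaches only the limit > 100000 nM. The step that the two limits leave unreadable from compound 2 to compound 3 therefore cannot be read, since both values sit at the limit of > 100000 nM in this assay, at which 2 of the 3 values shown sit. Compound 3 thus stands at the weak end of the numbers shown, without a number of its own.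

Compound 4 `O=C(c1cc(Oc2cccc(NC(=S)Nc3ccc(OC(F)(F)F)cc3)c2)ccn1)N1CCCC1` differs from compound 3 by pyrrolidin-1-yl in place of isopropylamino on a carbonyl carbon. Within the data shown here, no measured step covers this change on the same thiourea end; compound 1 shows only that the pyrrolidine amide with the other thiourea end is measurable but weak at 35400 nM. Because compound 3 rests at > 100000 nM, compound 4 is expected to stay weak, with the step of an at least 1.2-fold lower number from compound 3 to compound 4 (0.09 log units; that floor lies within the scatter) uncertain in size. The estimate for compound 4 in this assay is 80000 nM, ranging from 30000 nM to 200000 nM.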

Compound 4, half-maximal inhibitory concentration: 37800 nM
Compound 4: middle estimate off by 2.1-fold (0.33 log units), on the high side; measured number inside the range.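

At this carbonyl carbon, pyrrolidin-1-yl gives a measurable number on the 4-(trifluoromethoxy)phenyl end in this assay, with an at least 2.6-fold lower number from compound 3 to compound 4 (0.42 log units; beyond the scatter) and an at least 2.6-fold lower number from compound 2 to compound 4 (0.42 log units; beyond the scatter) as floors rather than full sizes. At a fixed pyrrolidine amide, the aryl end can now be compared: the change reads a 1.1-fold higher number from compound 1 to compound 4 (0.03 log units; within the scatter) and so does not separate 4-(trifluoromethoxy)phenyl from 3-(trifluoromethyl)phenyl. The step between the methyl and isopropyl amides still cannot be read: the limit of > 100000 nM in this assay, at which 2 of the 4 values shown sit.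

Neither dimethylamino nor piperidin-1-yl on this carbonyl is among the compounds shown, so the ring and the loss of the amide hydrogen cannot be told apart. Going by these compounds, how the 3-(trifluoromethyl)phenyl end behaves with a methyl or isopropyl amide also stays open.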